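The source may hold more compounds than are shown below. What is called first, only, known or untested is meant among the compounds shown, and "the series" means these compounds.

Measured in a functional assay on HOS-TE85 cells (Homo sapiens) for inhibition, read by CCK-8 assay, with a stated time of 72 h; on this read-out lower numbers stand for stronger inhibition and higher numbers for weaker inhibition:
- compound 1 `O=C(NCCCCc1ccccc1)c1cccc(C2SCC(=O)N2c2cnccn2)c1`: > 1000 nM
- compound 2 `COc1ccccc1N1C(=O)CSC1c1cc(C(=O)NCCCCc2ccccc2)cc(C2CC2)c1`: 23.5 nM
- compound 3 `COc1ccccc1N1C(=O)CSC1c1cc(F)cc(C(=O)NCCCCc2ccccc2)c1`: 40.9 nM

Compound 1 stands at > 1000 nM, which is a limit of the assay and not a number. Compound 4 `COc1ccc(F)cc1N1C(=O)CSC1c1cccc(C(=O)NCCCCc2ccccc2)c1` keeps the core of compound 1 but carries 5-fluoro-2-methoxyphenyl in place of pyrazin-2-yl on an amide-type nitrogen in a ring.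

For the measured compounds named here, no measured step isolates this swap. Going by the values given here, the only step available is a 1.7-fold higher number from compound 2 to compound 3 (0.24 log units; within the scatter), with fluoro in place of cyclopropyl on an aromatic carbon. It bears on the question only indirectly, since compound 4 has neither of those two groups on that carbon, and it suggests that this carbon need not decide the outcome. The better guide is that compounds 2 and 3 both carry a methoxy-bearing phenyl group on the same nitrogen, with compound 2 at 23.5 nM and compound 3 at 40.9 nM. The new group in compound 4 differs from theirs by its fluoro.

A large move toward a lower number, meaning stronger inhibition, is therefore expected, and the expected change is an at least 16-fold lower number from compound 1 to compound 4 (1.22 log units; beyond the scatter). For compound 4 the estimate is 60 nM, with an expected range from 15 nM to 250 nM.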

Compound 4, half-maximal inhibitory concentration: 8.8 nM
Compound 4: middle estimate off by 6.8-fold (0.83 log units), on the high side; the measured number lies below the stated range.
By their numbers in this assay, from the lowest: compound 4; then compounds 2 and 3 (each within the scatter of the next). At a limit, above all of these: compound 1.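

Placing 5-fluoro-2-methoxyphenyl instead of pyrazin-2-yl on the amide-type nitrogen in a ring gives, in this assay, an at least 110-fold lower number from compound 1 to compound 4 (2.05 log units; beyond the scatter), which shows that the group at this position can strongly change inhibition while the rest of the molecule stays the same. For the compounds shown here, none of the earlier compounds could show this, as the only single-place step among them concerned an aromatic carbon and left the group on this nitrogen out of the comparison. Compound 1 stands at a limit of the assay and not a number, so the step gives a minimum size and its true size stays unknown: the limit of > 1000 nM in this assay, at which 1 of the 4 values shown sits.

Since the whole group changes in one step, the compounds shown cannot separate the contributions of the methoxy, the fluoro and the loss of the nitrogen atoms of pyrazin-2-yl. Going by these compounds, how this position would respond to a plain unsubstituted phenyl, or to a phenyl carrying an amine or a carboxylic acid, also remains open.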